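The source may report more compounds than this note shows. Statements on the series, on what has been measured and on what is new or still open speak of the compounds shown alone.

Measured compounds:
- Compound 1, `CC(C)(C)c1ccc(C(=O)N2CCC3(CC2)C(=O)N(CC(=O)NCCO)CN3c2ccccc2)cc1`, gives 1000 nM in an assay on HEK293 cells for displacement of a labelled ligand from NPC1-like intracellular cholesterol transporter 1 (Homo sapiens); a lower number here means a stronger inhibitor, a higher number a weaker inhibitor.
- Compound 2, `CC1CCCN(C(=O)CN2CN(c3ccccc3)C3(CCN(C(=O)c4ccc(C5CCCCC5)cc4)CC3)C2=O)C1`, gives 3600 nM in the same assay.

Of the two measured compounds, compound 2 has the higher number, and its gap to compound 1 lies beyond the usual scatter of repeated measurements. Compound 1 carries a tert-butyl group on its aromatic ring, while compound 2 carries a cyclohexyl there; the two also differ in the chain on the other side of the shared core, so the gap between them cannot be assigned to one change alone.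

Compound 3, `CC1CCCN(C(=O)CN2CN(c3ccccc3)C3(CCN(C(=O)c4ccc(C(C)(C)C)cc4)CC3)C2=O)C1`, keeps the whole of compound 2 except for one change: tert-butyl in place of cyclohexyl on an aromatic carbon. This brings the aromatic end of compound 3 in line with that of compound 1 while retaining the chain of compound 2.

Given that compound 1 shows the lower number, a modest move toward lower numbers is expected, though the step from compound 2 to compound 3 is estimated at a 1.8-fold lower number from compound 2 to compound 3 (0.26 log units; within the scatter) and may well fall within the scatter. Compound 3 is expected to give about 2000 nM, with a range from 700 nM to 6000 nM.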

Compound 3, half-maximal inhibitory concentration: 12000 nM
Compound 3: middle estimate off by 6.0-fold (0.78 log units), on the low side; measured number outside the range, above it.
By their numbers in this assay, from the lowest: compound 1; then compound 2; then compound 3.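

In this assay, the exchange on the aromatic carbon para to a large group is not neutral: with the 3-methylpiperidin-1-yl chain held constant, replacing cyclohexyl by tert-butyl gives a 3.3-fold higher number from compound 2 to compound 3 (0.52 log units; beyond the scatter), so on this chain the ring-bearing group goes with the lower number. With tert-butyl held constant instead, the other end of the molecule also proves sensitive, as 3-methylpiperidin-1-yl in place of (2-hydroxyethyl)amino on the carbonyl carbon gives a 12-fold higher number from compound 1 to compound 3 (1.08 log units; beyond the scatter), a large step in the same direction of weaker inhibition. Nothing available here gives a reason for either step.

From the compounds shown here alone, the two aromatic groups are compared on one chain only, so it remains open whether cyclohexyl would also give a lower number than tert-butyl on the (2-hydroxyethyl)amino chain, or whether the two ends of the molecule act independently. Going by these compounds, it also remains open how other groups would read in these two places, such as a phenyl ring on the aromatic carbon, or a morpholine or a longer hydroxyalkyl amine on the carbonyl carbon.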